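Trifluoromethyl for fluoro on two related cores

A few compounds are considered here, and "the series" means these few. Any claim that something is new, unique, unknown or untested is made for them only; others in the source may bear on it.

Measured compounds:
compound 1, `O=C(Nc1ccc(Oc2ccnc3[nH]ccc23)cc1)c1nn(-c2ccc(Cl)c(F)c2)ccc1=O`, 5240 nM
compound 2, `O=C(Nc1ccc(Oc2ccnc3[nH]ccc23)cc1)c1nn(-c2ccc(Cl)c(C(F)(F)F)c2)ccc1=O`, 1320 nM
compound 3, `Cn1ccc2c(Oc3ccc(NC(=O)c4nn(-c5ccc(Cl)c(F)c5)ccc4=O)cc3F)ccnc21`, 22100 nM

This account concerns four compounds tested, or to be tested, in a functional assay on HepG2 cells (Homo sapiens) for cytotoxicity, read by MTT assay, with a stated time of 72 h; on this read-out lower numbers stand for stronger inhibition and higher numbers for weaker inhibition. Compound 1 gives 5240 nM in this assay. Compound 2 carries a trifluoromethyl where compound 1 carries a fluoro; the change is trifluoromethyl in place of fluoro on an aromatic carbon, and it brought a 4.0-fold lower number from compound 1 to compound 2 (0.60 log units; beyond the scatter), with compound 2 at 1320 nM.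

Compound 3 is built on a different core; how the two cores differ is not broken down here. In this assay compound 3 gives 22100 nM, the highest number among the three measured compounds. Compound 4, `Cn1ccc2c(Oc3ccc(NC(=O)c4nn(-c5ccc(Cl)c(C(F)(F)F)c5)ccc4=O)cc3F)ccnc21`, is not yet measured. It stands to compound 3 as compound 2 stands to compound 1: trifluoromethyl in place of fluoro on an aromatic carbon. The two place descriptions read the same word for word, so this is the same change made on the other core.

For the measured compounds named here, with only one measured instance of this change, the expectation for compound 4 rests on that single step. The step from compound 3 to compound 4 in this assay is expected to be about a 3.7-fold lower number from compound 3 to compound 4 (0.57 log units; beyond the scatter), resting on the step of a 4.0-fold lower number from compound 1 to compound 2 (0.60 log units; beyond the scatter) on the core of compound 1. Compound 4 is therefore estimated at 6000 nM, with a plausible range from 2500 nM to 15000 nM.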

Compound 4, half-maximal inhibitory concentration: 13500 nM
Compound 4: middle estimate off by 2.3-fold (0.35 log units), on the low side; the range from low to high includes it.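

In this assay the change from fluoro to trifluoromethyl on the core of compound 3 gives a 1.6-fold lower number from compound 3 to compound 4 (0.21 log units; within the scatter) and so cannot be told apart from repeat measurement on this core, whereas the same change on the core of compound 1 stands beyond the scatter. Even so, the two steps cannot be separated from each other: the same change on two cores in this assay, a 4.0-fold lower number (0.60 log units; beyond the scatter) from compound 1 to compound 2 and a 1.6-fold lower number (0.21 log units; within the scatter) from compound 3 to compound 4, 2.4-fold (0.38 log units) apart, within the scatter of two such steps. For the compounds shown here, this shows that the series gives no firm sign of the step depending on the core, but it does not show that the step carries over unchanged, for each core supplies only a single pair and the step on the core of compound 3 is not distinguishable from no step at all.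

The compounds shown vary only fluoro and trifluoromethyl at this one place, with the chloro group kept throughout, so they leave open how an amine, a nitrile or a methoxy group there would behave on either core. They also leave open whether any other single change would carry from one core to the other, and which of the several differences between the two cores matters in this read-out.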